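The compounds below may be only part of what the source reports. "The series", "measured", "known", "first", "only" and "open" are said of these compounds alone.

Three compounds sharing one core differ only in the aryl group on a saturated chain carbon bound to a nitrogen on an aromatic ring. In a functional assay on K562 cells (Homo sapiens) for antiproliferative activity, with a stated time of 72 h (a higher number here means a weaker inhibitor, a lower number a stronger inhibitor), compound 1 `Cc1cccc(CNc2ncnc3c2ncn3[C@@H]2O[C@H](CO)[C@@H](O)[C@H]2O)c1`, with 3-methylphenyl, gives > 166000 nM, which is a limit and not a number. Compound 2 `OC[C@H]1O[C@@H](n2cnc3c(NCc4ccc(F)cc4F)ncnc32)[C@H](O)[C@@H]1O`, with 2,4-difluorophenyl, gives 9600 nM. This is a large change: an at least 17-fold lower number from compound 1 to compound 2 (1.23 log units; beyond the scatter). Compound 3 `OC[C@H]1O[C@@H](n2cnc3c(NCc4c(F)ccc(F)c4F)ncnc32)[C@H](O)[C@@H]1O`, with 2,3,6-trifluorophenyl, gives > 166000 nM, again a limit. It therefore stands at the limit of > 166000 nM in this assay, at which 2 of the 3 values shown sit. The fluorine pattern alone produced an at least 17-fold higher number from compound 2 to compound 3 (1.23 log units; beyond the scatter), whereas the other step is a step that the two limits leave unreadable from compound 1 to compound 3.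

Compound 4 `OC[C@H]1O[C@@H](n2cnc3c(NCc4cccc(O)c4O)ncnc32)[C@H](O)[C@@H]1O` brings a further change: 2,3-dihydroxyphenyl in place of 2,3,6-trifluorophenyl on a saturated chain carbon bound to a nitrogen on an aromatic ring. Among the measured compounds shown here, no measured step involves 2,3-dihydroxyphenyl, so the expectation rests on the large swings above and on compound 2, the only compound with a number, at 9600 nM. The expected change in this assay is an at least 4.1-fold lower number from compound 3 to compound 4 (0.61 log units; beyond the scatter), towards a lower number but of uncertain size. Compound 4 is estimated at 40000 nM, with an expected range from 4000 nM to 166000 nM.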

Compound 4, half-maximal inhibitory concentration: 25800 nM
For compound 4 the middle estimate is 1.6-fold (0.19 log units) above the measured one; the measured number falls inside the stated range.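

At this place, on a saturated chain carbon bound to a nitrogen on an aromatic ring, a readable number in this assay no longer requires a fluorinated aryl group: 2,3-dihydroxyphenyl gives an at least 6.4-fold lower number from compound 3 to compound 4 (0.80 log units; beyond the scatter) against 2,3,6-trifluorophenyl and an at least 6.4-fold lower number from compound 1 to compound 4 (0.80 log units; beyond the scatter) against 3-methylphenyl. Both of these steps start from a limit and not from a number, so they fix only a smallest size: the limit of > 166000 nM in this assay, at which 2 of the 4 values shown sit. The 2,3-dihydroxyphenyl group does not match 2,4-difluorophenyl, however, as the change shows a 2.7-fold higher number from compound 2 to compound 4 (0.43 log units; beyond the scatter), so the two readable aryl groups remain apart.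

The compounds shown leave open whether both hydroxy groups are needed for this gain, since no aryl group with a single hydroxy group appears among them. They also leave open how a methoxy group, an amine or a carboxylic acid on the aryl ring would compare.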